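The source may hold more compounds than are shown below. What is called first, only, known or untested is meant among the compounds shown, and "the series" means these compounds.

Of the compounds shown here, three have so far been tested in a functional assay (Homo sapiens) for inhibition of Nucleic Acid, tested at 100 uM; on this read-out higher numbers stand for more inhibition at the one concentration tested (going by the name of the read-out) and lower numbers for less inhibition. Compound 1 `Clc1[nH]ccc2ncnc1-2` gives 6%, compound 2 `OC[C@H]1O[C@@H](n2cnc3c(S)nccc32)C[C@@H]1O` gives 10%, and compound 3 `c1ccc(Nc2[nH]ccc3ncnc2-3)cc1` gives 12%. Compound 2 sits among these three, and none of them differs from another beyond the usual scatter of such measurements. Compound 4 `OC[C@H]1O[C@@H](n2cnc3cnccc32)C[C@@H]1O` has not yet been measured in this assay. It differs from compound 2 in one place: hydrogen in place of sulfanyl on an aromatic carbon. Among the measured compounds shown here, no pair of measured compounds differing in a single place is available, so nothing shows how this kind of change shifts the number. All three measured compounds sit low. The step from compound 2 to compound 4 is therefore expected to stay within the scatter, in no clear direction. Compound 4 is expected to give 8%, within a range from 0% to 20%. The step this estimate means, a number 2 percentage points lower from compound 2 to compound 4 (within the scatter), is expected to be small.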

Compound 4, a percentage reported as inhibition, at one concentration (the size of the read-out at that concentration, not a potency): 6%
For compound 4 the middle estimate is 2 percentage points above the measured one; the measured number falls inside the stated range.
By their numbers in this assay, from the lowest: compounds 1, 4, 2 and 3 (each within the scatter of the next).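

Hydrogen in place of sulfanyl on this aromatic carbon gives the first comparison of compounds differing in one place in this assay (a number 4 percentage points lower from compound 2 to compound 4 (within the scatter)). At this position next to the ring nitrogen, losing the sulfanyl group therefore produces no step beyond the scatter, and this single pair gives no sign that the group matters to the read-out. No measurement available here bears on why this is so. Going by these compounds, whether an amine or a methoxy group on this same carbon would give a number clearly apart from these stays open.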